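Compound 3: from 4-chlorophenyl to 3-bromophenyl

The source may hold more compounds than are shown below. What is called first, only, known or untested is meant among the compounds shown, and "the series" means these compounds.

Measured so far in a functional assay on HT-1080 cells (Homo sapiens) for cytotoxicity, read by MTT assay, with a stated time of 72 h; a lower number here means a stronger inhibitor, a higher number a weaker inhibitor:
- compound 1 `COc1cccc(/C=C2\CCC/C(=C\c3cccc(Cl)c3)C2=O)c1OC` gives 10300 nM
- compound 2 `COc1cccc(/C=C2\CCC/C(=C\c3ccc(Cl)cc3)C2=O)c1OC` gives 11100 nM

Compound 2 has only compound 1 to stand against in this assay and the two cannot be ordered. Among the compounds with values here, the single measured step is a 1.1-fold higher number from compound 1 to compound 2 (0.03 log units; within the scatter) and it is the only one that bears on what follows. Compound 3 `COc1cccc(/C=C2\CCC/C(=C\c3cccc(Br)c3)C2=O)c1OC` has not yet been measured. The change leading to it is 3-bromophenyl in place of 4-chlorophenyl on a double-bonded chain carbon bound to a double-bonded ring carbon and it falls on a double-bonded chain carbon bound to a double-bonded ring carbon. Part of this change resembles the measured step, which exchanged 3-chlorophenyl for 4-chlorophenyl and stayed within the scatter. Within the data shown here, the bromine has no measured precedent, since neither measured compound carries it, so that part of the expectation rests on no data. Among the measured compounds shown here, a small effect is nevertheless expected because a 1.1-fold higher number from compound 1 to compound 2 (0.03 log units; within the scatter) is the only evidence available. The expected step is a 1.2-fold lower number from compound 2 to compound 3 (0.07 log units; within the scatter) and no change beyond the scatter is anticipated. Compound 3 is estimated at 9500 nM with an expected range from 4500 nM to 20000 nM in this assay when it is measured.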

Compound 3, half-maximal inhibitory concentration: 12200 nM
Beside the measured number, compound 3's estimate is 1.3-fold (0.11 log units) below it; low and high end bracket the measured number.
By their numbers in this assay, from the lowest: compounds 1, 2 and 3 (each within the scatter of the next).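

Bromo in place of chloro on an aromatic carbon gives a 1.2-fold higher number from compound 1 to compound 3 (0.07 log units; within the scatter) in this assay and is the first measured exchange of the halogen alone, showing that chloro and bromo cannot be told apart at this carbon. The change from 4-chlorophenyl to 3-bromophenyl on a double-bonded chain carbon bound to a double-bonded ring carbon alters both the halogen and the name of the substituted phenyl group, yet it gives a 1.1-fold higher number from compound 2 to compound 3 (0.04 log units; within the scatter) and no separation appears. Thus 3-chlorophenyl, 4-chlorophenyl and 3-bromophenyl remain unordered at this place, and nothing shown here offers an explanation for the absence of a difference.

The three compounds leave open whether 4-bromophenyl would also remain within the scatter of these compounds, which would complete the comparison of the two halogens in both named arrangements. They also leave open whether a phenyl group carrying an amine or a carboxylic acid instead of chloro or bromo would shift the number in this assay beyond the scatter at this place on the shared core.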